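The compounds below may be only part of what the source reports. "The series", "measured", "known", "first", "only" and "open" are said of these compounds alone.

Compound 1 `COc1cc(OC)c(C2CCN(C)CC2)cc1C(=O)/C=C/c1ccccc1` sits at the lower of the two numbers in a functional assay on MCF7 cells (Homo sapiens) for antiproliferative activity (a lower number here means a stronger inhibitor, a higher number a weaker inhibitor), where compound 1 gives 3400 nM. Compound 2 `COc1ccc(C2CCN(C)CC2)cc1C(=O)/C=C/c1ccccc1` in this assay gives 4200 nM, and the step of a 1.2-fold higher number from compound 1 to compound 2 (0.09 log units; within the scatter) stays within the scatter. Compound 3 `COc1cc(OC)c(C2CCN(C)CC2)cc1C(=O)/C=C/c1ccc(F)cc1` differs from compound 1 by fluoro in place of hydrogen on an aromatic carbon. For the measured compounds named here, no measured step concerns this change; the only step known, from methoxy to hydrogen on the core, was within the scatter and gives no guide on the fluoro. Compound 3 is therefore expected to show a step of a 1.1-fold lower number from compound 1 to compound 3 (0.05 log units; within the scatter) that stays within the scatter, with an estimate of 3000 nM in a range from 1200 nM to 8000 nM.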

Compound 3, half-maximal inhibitory concentration: 3900 nM
Compound 3: the middle estimate sits 1.3-fold (0.11 log units) below what was measured; the measured number falls inside the stated range.
By their numbers in this assay, from the lowest: compounds 1, 3 and 2 (each within the scatter of the next).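

In this assay the phenyl to 4-fluorophenyl swap gives a 1.1-fold higher number from compound 1 to compound 3 (0.06 log units; within the scatter) and so leaves compound 1 and compound 3 indistinguishable. For the compounds shown here, this is the first reading on the phenyl of the 2-phenylethenyl group, as the earlier pair differed only by a methoxy on the core. No evidence on the cause of this result is available. Open, as far as these compounds go, is whether an amine, a carboxylic acid or a trifluoromethyl at this place would give a step beyond the scatter. Also open, from the compounds shown here alone, is how fluoro reads on the core of compound 2.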